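Methyl to fluoro on the phenol ring of compound 1

The compounds below may be only part of what the source reports. "The series", "measured", "known", "first", "only" and "open" are said of these compounds alone.

Measured so far:
compound 1, `Cc1ccc(O)c(-c2nc(N[C@H]3CCNC3)c3ccccc3n2)c1`, 92 nM
compound 2, `COc1cc2nc(-c3ccccc3O)nc(N[C@H]3CCNC3)c2cc1OC`, 28 nM

Both numbers come from an assay on isolated protein for inhibition of serine/threonine-protein kinase Chk2 (Homo sapiens); a lower number here means a stronger inhibitor, a higher number a weaker inhibitor. Of the two, compound 1 carries the highest number; compound 2 sits lower, and the gap between the two values is beyond the usual scatter. The two compounds differ in more than one place, so the gap cannot be tied to a single change.

Compound 3, `Oc1ccc(F)cc1-c1nc(N[C@H]2CCNC2)c2ccccc2n1`, differs from compound 1 by fluoro in place of methyl on an aromatic carbon. Among the measured compounds shown here, no measured pair shows the effect of this exchange, so nothing here points to a large movement in either direction. The step is expected to stay within the usual scatter, estimated at a 1.1-fold higher number from compound 1 to compound 3 (0.04 log units; within the scatter). For compound 3 the estimate in this assay is 100 nM, with a range from 40 nM to 250 nM.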

Compound 3, half-maximal inhibitory concentration: 60 nM
Beside the measured number, compound 3's estimate is 1.7-fold (0.22 log units) above it; the measured number falls inside the stated range.
By their numbers in this assay, from the lowest: compound 2; then compounds 3 and 1 (each within the scatter of the next).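

In this assay, among the compounds shown here, the change from 2-hydroxy-5-methylphenyl to 5-fluoro-2-hydroxyphenyl gives a 1.5-fold lower number from compound 1 to compound 3 (0.19 log units; within the scatter) and is the first single-place comparison. The position para to a hydroxy group therefore accepts fluoro in place of methyl with no change that can be told from the usual scatter, so this one exchange does not separate the two groups. Nothing measured on these compounds gives a reason for this outcome.

On these data alone, whether this position stays as flat with a larger or differently built group, such as methoxy, nitrile or an amine, remains open. Compound 2 differs from compound 3 in more than one place, so the shown compounds also leave open how the fluoro group would behave alongside the methoxy groups of compound 2.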